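The compounds below may be only part of what the source reports. "The series", "measured", "known", "first", "only" and "open" are said of these compounds alone.

Measured so far in a functional assay on SiHa cells (Homo sapiens) for cytotoxicity, read by MTT assay, with a stated time of 48 h; a lower number here means a stronger inhibitor, a higher number a weaker inhibitor:
compound 1 `CCCCCCCCCCCCCCNC(=O)[C@@H](N)[C@@H](C)O` gives 11000 nM
compound 2 `CCCCCCCCNC(=O)[C@@H](NC(=O)c1ccco1)[C@@H](C)O` gives 124000 nM
compound 3 `CCCCCCCCNC(=O)[C@@H](NC(=O)c1nccc2ccccc12)[C@@H](C)O` gives 66000 nM

Compound 2 has the highest number of the three in this assay. Its gap to compound 3 is within the scatter; its gap to compound 1 is beyond it, with compound 1 at the lower number. Among the compounds with values here, no single-point steps between measured compounds are available to calibrate the move to compound 4 `CCCCCCCCNC(=O)[C@@H](NC(=O)/C=C/c1ccccc1)[C@@H](C)O`. The change is 2-phenylethenyl in place of furan-2-yl on a carbonyl carbon. Compound 2 and compound 3 lie within the scatter of each other, so the series gives no sign that a change at this amide shifts the number far. For compound 4 the expected step is a 2.1-fold lower number from compound 2 to compound 4 (0.32 log units; beyond the scatter), a modest move toward a lower number at most. The estimate for compound 4 is 60000 nM, within 20000 nM to 200000 nM.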

Compound 4, half-maximal inhibitory concentration: 41400 nM
Compound 4: the middle estimate sits 1.4-fold (0.16 log units) above what was measured; low and high end bracket the measured number.
By their numbers in this assay, from the lowest: compound 1; then compounds 4, 3 and 2 (each within the scatter of the next, the first and the last beyond it).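

In this assay, within the data shown here, replacing furan-2-yl with 2-phenylethenyl on this carbonyl carbon gives a 3.0-fold lower number from compound 2 to compound 4 (0.48 log units; beyond the scatter) and provides the first single-change measurement at this place. A change here can therefore move the number beyond the scatter, although this step is only modest. No measured evidence bears on what lies behind the step. As far as these compounds go, it remains open whether an amine or a carboxylic acid in place of 2-phenylethenyl on this carbonyl carbon would shift the number further, and whether the same step would hold with a longer chain on the shared core.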